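The source may report more compounds than this note shows. Statements on the series, on what has been measured and on what is new or still open speak of the compounds shown alone.

Within the data shown here, compound 3 `OC(CCn1nc2c(Br)c(Br)c(Br)c(Br)c2n1)c1cccc(Cl)c1` gives 107% in a functional assay on MCF7 cells (Homo sapiens) for antiproliferative activity, read by MTT assay, with a stated time of 48 h, tested at 12.5 uM; on this read-out lower numbers stand for a stronger effect and higher numbers for a weaker effect at the one concentration tested; it stands second highest of the three numbers so far, with compound 2 nearest and compound 1 furthest, both within the scatter. Compound 1 `OC(CCn1nc2c(Br)c(Br)c(Br)c(Br)c2n1)c1cccc(Br)c1` gives 102%, and compound 2 `OC(CCn1nc2c(Br)c(Br)c(Br)c(Br)c2n1)c1ccc(F)cc1` gives 109%. Compound 4 `OC(CCn1nc2c(Br)c(Br)c(Br)c(Br)c2n1)c1ccccc1` differs from compound 3 by hydrogen in place of chloro on an aromatic carbon. Among the measured compounds shown here, the steps that bear on this change are those on the same aromatic ring: a number 5 percentage points higher from compound 1 to compound 3 (within the scatter), a number 7 percentage points higher from compound 1 to compound 2 (within the scatter) and a number 2 percentage points lower from compound 2 to compound 3 (within the scatter), each within the scatter. None of the halogen swaps or ring exchanges among these three compounds moved the read-out beyond its noise, so removal of the chloro is expected to do no more: the step of a number 2 percentage points lower from compound 3 to compound 4 (within the scatter) is estimated to lie within the scatter, in no clear direction. Compound 4 is therefore expected to give 105%, between 95% and 115%, because compound 3 gives 107% and its neighbours sit close by.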

Compound 4, a percentage reported as activity, at one concentration (the size of the read-out at that concentration, not a potency): 113%
Estimate against measurement, compound 4: 8 percentage points below; low and high end bracket the measured number.
By their numbers in this assay, from the lowest: compounds 1, 3, 2 and 4 (each within the scatter of the next, the first and the last beyond it).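

Replacing the chloro with hydrogen does not separate the two compounds in this assay, with a number 6 percentage points higher from compound 3 to compound 4 (within the scatter), and replacing the fluoro gives the same outcome, with a number 4 percentage points higher from compound 2 to compound 4 (within the scatter). Among these compounds, only the bromo exchange clears the noise, with a number 11 percentage points higher from compound 1 to compound 4 (beyond the scatter), the first step to do so: a modestly weaker effect for the unsubstituted phenyl than for the 3-bromophenyl, a contrast that compound 2 and compound 3 do not share. No measurement offered here explains why the bromo alone stands apart.

From the compounds shown here alone, it remains open whether an amine or a carboxylic acid on the aromatic ring would lower the number at all. A longer chain between the shared core and the hydroxyl-bearing carbon is equally untested by these compounds.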